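Benzyl ether variation on a bis-aryloxyethylamine series

The compounds below may be only part of what the source reports. "The series", "measured", "known", "first", "only" and "open" are said of these compounds alone.

Measured compounds:
compound 1, `COc1cccc(OC)c1OCCNCCOc1ccccc1OCc1cccc(Cl)c1`, 0.159 nM
compound 2, `COc1cccc(OC)c1OCCNCCOc1ccccc1OCc1cccc([N+](=O)[O-])c1`, 0.794 nM
compound 3, `COc1cccc(OC)c1OCCNCCOc1ccccc1OCc1ccc([N+](=O)[O-])cc1`, 0.398 nM

All three share one core and differ only in the aryl group of the benzyl ether. In an assay on CHO cells for displacement of a labelled ligand from Alpha-1B adrenergic receptor (Homo sapiens) (a higher number here means a weaker inhibitor, a lower number a stronger inhibitor), compound 3 gives 0.398 nM, the second highest of the three numbers; its nearest neighbour is compound 2, and the gap between them, a 2.0-fold lower number from compound 2 to compound 3 (0.30 log units; within the scatter), is within the scatter, so no order between these two is claimed. For the measured compounds named here, the one change that clearly moves the number is a 2.5-fold higher number from compound 1 to compound 3 (0.40 log units; beyond the scatter), which places compound 1 as the strongest of the set; the same holds for a 5.0-fold higher number from compound 1 to compound 2 (0.70 log units; beyond the scatter).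

Compound 4, `COc1ccccc1COc1ccccc1OCCNCCOc1c(OC)cccc1OC`, is not yet measured. It differs from compound 3 by 2-methoxyphenyl in place of 4-nitrophenyl on a saturated chain carbon bound to an oxygen on an aromatic ring. Going by the values given here, no measured step exchanges a nitro group for a methoxy group, so the bearing steps are indirect: the two exchanges of the aryl group already seen moved this assay only modestly, and the two nitro-bearing compounds sit close together. Compound 4 is therefore expected to land near compound 3, with the estimated step of a 1.3-fold lower number from compound 3 to compound 4 (0.12 log units; within the scatter) not clearly beyond the scatter. The estimate for compound 4 in this assay is 0.3 nM, within 0.08 nM to 1.2 nM.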

Compound 4, inhibition constant: 6.31 nM
Compound 4: the middle estimate sits 21-fold (1.32 log units) below what was measured, and the stated range ends below it.
By their numbers in this assay, from the lowest: compound 1; then compounds 3 and 2 (each within the scatter of the next); then compound 4.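

In this assay the aryl group of the benzyl ether turns out to carry far more of the number than the chloro and nitro compounds showed: 2-methoxyphenyl in place of 4-nitrophenyl gives a 16-fold higher number from compound 3 to compound 4 (1.20 log units; beyond the scatter), in place of 3-nitrophenyl it gives a 7.9-fold higher number from compound 2 to compound 4 (0.90 log units; beyond the scatter), and in place of 3-chlorophenyl it gives a 40-fold higher number from compound 1 to compound 4 (1.60 log units; beyond the scatter). For the compounds shown here, this position, on a saturated chain carbon bound to an oxygen on an aromatic ring, is therefore less forgiving than the earlier steps suggested, and compound 4 is the weakest of the four, with its steps to all the others printed as beyond the scatter. Nothing available offers an explanation for this loss, so it stands as an observation only.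

With one methoxy compound in the set, the compounds shown cannot separate the methoxy group itself from its place on the ring as the source of these steps. They also leave open how an unsubstituted phenyl, an amine or a carboxylic acid on this benzyl ether would read in this assay.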